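The compounds below may be only part of what the source reports. "The series", "measured", "known", "first", "only" and "open" are said of these compounds alone.

Measured so far in a functional assay on MCF7 cells (Homo sapiens) for inhibition, read by sulforhodamine B assay, with a stated time of 48 h, tested at 50 uM; on this read-out lower numbers stand for less inhibition of growth and higher numbers for more inhibition of growth at the one concentration tested:
compound 1 `CCCOc1ccc([C@@H]2CC(=O)c3cc(CC=C(C)C)c(OC)cc3O2)cc1`: 60%
compound 2 `COc1ccc([C@@H]2CC(=O)c3cc(CC=C(C)C)c(OC)cc3O2)cc1`: 65%
compound 3 `COc1ccc([C@@H]2C/C(=N/O)c3cc(CC=C(C)C)c(OC)cc3O2)cc1`: 63%

Compound 2, at 65%, is the starting point here. Its gaps to compound 1 and to compound 3 both lie within the usual scatter of this assay, so these data do not set it apart from either.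

Compound 4 `COc1cc2c(cc1CC=C(C)C)C(=O)C[C@@H](c1ccc(Oc3ccc(F)cc3)cc1)O2` has not yet been measured. It differs from compound 2 as follows: 4-fluorophenyl in place of methyl on an oxygen on an aromatic ring. In words, this is 4-fluorophenyl in place of methyl on an oxygen on an aromatic ring, or methoxy to 4-fluorophenoxy.

Among the measured compounds shown here, only one measured step changes the group on that oxygen: a number 5 percentage points higher from compound 1 to compound 2 (within the scatter). That step is small and concerns only a saturated chain, so it says little about the entry of a whole aromatic ring. For the measured compounds named here, no measured compound carries such a ring on that oxygen, and the direction of any change remains open.

Going by the values given here, with only that step as a guide, no step beyond the scatter is expected, and the expected step is a number 5 percentage points lower from compound 2 to compound 4 (within the scatter). The estimate for compound 4 is 60%, with an expected range from 40% to 80%.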

Compound 4, percent growth inhibition at one concentration: 37%
For compound 4 the middle estimate is 23 percentage points above the measured one; the whole stated range lies above it.
By their numbers in this assay, from the lowest: compound 4; then compounds 1, 3 and 2 (each within the scatter of the next).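

In this assay, changing the saturated chain on the oxygen on the aromatic ring had shown little, with a number 5 percentage points higher from compound 1 to compound 2 (within the scatter). An aromatic ring in that place gives a clearer result: going from methoxy to 4-fluorophenoxy gives a number 28 percentage points lower from compound 2 to compound 4 (beyond the scatter), and replacing propyl with 4-fluorophenyl gives a number 23 percentage points lower from compound 1 to compound 4 (beyond the scatter), so this position is not indifferent to the group it carries, and both steps with the ring point to less growth inhibition at the one concentration tested. Nothing available here shows why the number falls with this change.

Going by these compounds, whether the loss goes with the aromatic ring as such or with its fluorine remains open, and a plain phenyl on that oxygen would separate the two, while a chain ending in an amine or a carboxylic acid would test a quite different kind of group there. On these data alone, it is also open whether the same change would lower the number on compound 3, and how much of the pattern would hold at concentrations other than the single one used here.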